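Swapping the alkynyl linker for a fluorophenyl ring

This account rests on a few compounds, and the source may have more. Where it says the series, first, only, none or still open, it means among the compounds named here.

Measured compounds:
- compound 1 `CCCC#Cc1cc([C@@H]2O[C@H](CO)[C@@H](O)[C@H]2O)n2ncnc(N)c12`: 20 nM
- compound 2 `CCCCC#Cc1cc([C@@H]2O[C@H](CO)[C@@H](O)[C@H]2O)n2ncnc(N)c12`: 1000 nM
- compound 3 `Nc1ncnn2c([C@@H]3O[C@H](CO)[C@@H](O)[C@H]3O)cc(C#Cc3ccccc3)c12`: 37700 nM

All three share one nucleoside-like core and differ only in the group attached to it. In a functional assay on CAPAN-1 cells (Homo sapiens) for antiproliferative activity, with a stated time of 72 h (a higher number here means a weaker inhibitor, a lower number a stronger inhibitor), compound 3 gives the highest number of the three, so it is the weakest inhibitor here. The step of a 38-fold higher number from compound 2 to compound 3 (1.58 log units; beyond the scatter) and the step of a 1900-fold higher number from compound 1 to compound 3 (3.28 log units; beyond the scatter) were both large, and the step of a 50-fold higher number from compound 1 to compound 2 (1.70 log units; beyond the scatter) shows that even a small extension of the chain costs much.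

Compound 4 `Nc1ncnn2c([C@@H]3O[C@H](CO)[C@@H](O)[C@H]3O)cc(-c3ccccc3F)c12` is not yet measured. The change from compound 3 is 2-fluorophenyl in place of 2-phenylethynyl on an aromatic carbon. For the measured compounds named here, no measured step removes the triple bond, so the only guidance is that compound 3, the one aromatic member, stands far weaker than the two alkyl members. A directly attached ring with one fluorine is a new kind of group, and the data give no steady direction for it, so only a small step in either direction, within or near the scatter, is expected as a 1.3-fold higher number from compound 3 to compound 4 (0.12 log units; within the scatter). Compound 4 is therefore estimated at 50000 nM in this assay, with a range from 8000 nM to 300000 nM.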

Compound 4, half-maximal inhibitory concentration: > 100000 nM
Compound 4 ended at the assay's limit; the forecaster's own chance of this, stated with the estimate: 25%; middle value at least 2.0-fold (0.30 log units) from the limit.
By their numbers in this assay, from the lowest: compound 1; then compound 2; then compound 3. At a limit, above all of these: compound 4.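

In this assay, compound 4 stands at a limit and not at a number: the limit of > 100000 nM in this assay, at which 1 of the 4 values shown sits. Exchanging 2-phenylethynyl for 2-fluorophenyl on this aromatic carbon gives an at least 2.6-fold higher number from compound 3 to compound 4 (0.42 log units; beyond the scatter), so losing the triple bond while keeping a six-membered aromatic ring at this position brings no return of activity. Against the two chain-bearing alkynes, the gap is far wider, with an at least 100-fold higher number from compound 2 to compound 4 (2.00 log units; beyond the scatter) and an at least 5000-fold higher number from compound 1 to compound 4 (3.69 log units; beyond the scatter), and both compounds with an aromatic ring, compound 3 and compound 4, give higher numbers than the hex-1-yn-1-yl and pent-1-yn-1-yl compounds, with no compound among the four going against this.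

From the compounds shown here alone, the step from compound 3 to compound 4 removes the triple bond and adds a fluorine at the same time, so the effect of each alone stays unknown, as does how far past the limit compound 4 really lies. Also open, going by these compounds, is whether a plain phenyl on this carbon, a saturated pentyl chain without the triple bond, or a shorter alkyne such as but-1-yn-1-yl would give a lower number than compound 4.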